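A methyl for a methoxy on the shared core

The source may report more compounds than this note shows. Statements on the series, on what has been measured and on what is new or still open speak of the compounds shown alone.

Measured so far in an assay on isolated protein for inhibition of phosphatidylinositol 4,5-bisphosphate 3-kinase catalytic subunit beta isoform (Homo sapiens); on this read-out lower numbers stand for stronger inhibition and higher numbers for weaker inhibition:
Compound 1, `COc1ccc(-c2ccnc(Nc3ccc(Cl)cc3Cl)n2)cc1`: 839 nM
Compound 2, `Clc1ccc(Nc2nccc(-c3ccc(Cl)cc3Cl)n2)c(Cl)c1`: 799 nM
Compound 3, `COc1ccc(-c2ccnc(Nc3cccc(OC)c3)n2)cc1`: 729 nM

Compound 1 gives the highest of these three numbers, but its gaps to compound 2 and to compound 3 both fall within the usual scatter of repeated measurements, so the three compounds cannot be told apart on this read-out.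

Compound 4, `Cc1ccc(-c2ccnc(Nc3ccc(Cl)cc3Cl)n2)cc1`, has not yet been measured. It differs from compound 1 in one place: methyl in place of methoxy on an aromatic carbon. Among the compounds with values here, no pair among the measured compounds shows this change, so there is no measured step to lean on. What the three measured compounds do show is that changing the group on the outer ring, or the partner ring on the other side of the shared core, left the numbers close together.

Compound 4 is therefore expected to land near compound 1, with a step from compound 1 to compound 4 of about a 1.1-fold higher number from compound 1 to compound 4 (0.03 log units; within the scatter), in no particular direction beyond the scatter. The estimate for compound 4 in this assay is 900 nM, with a likely range from 300 nM to 2700 nM.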

Compound 4, half-maximal inhibitory concentration: > 1000 nM
Compound 4: no number, only a limit; the forecaster's own chance of this, stated with the estimate: 5%; at least 1.1-fold (0.04 log units) between middle value and limit.
By their numbers in this assay, from the lowest: compounds 3, 2 and 1 (each within the scatter of the next). At a limit, above all of these: compound 4.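

Compound 1 and compound 4 are the first pair shown that differs in one place, which gives the first direct reading of the group para to a large group in this assay. Replacing methoxy with methyl there gives an at least 1.1-fold higher number from compound 1 to compound 4 (0.07 log units; that floor lies within the scatter) and so points only towards weaker inhibition, with no sign of a gain, though that floor alone cannot separate the two compounds. Compound 4 is the only compound shown that reads as a limit and not as a number: the limit of > 1000 nM in this assay, at which 1 of the 4 values shown sits.

From the compounds shown here alone, how far the true value of compound 4 lies from that of compound 1 remains unknown. Also open, going by these compounds, is how other groups at this position would read, such as an amine, a hydroxyl or a longer chain like ethoxy, and whether any would give a clearly lower number than compound 1.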